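Working notes: from compound 2 to compound 3

A few compounds are considered here, and "the series" means these few. Any claim that something is new, unique, unknown or untested is made for them only; others in the source may bear on it.

Going by the values given here, in a functional assay (Platelet, plasma) for inhibition, with Homo sapiens as the target (on this read-out higher numbers stand for weaker inhibition and lower numbers for stronger inhibition), compound 1 (`N#Cc1cc2c(nc1N1CCC(C(=O)NS(=O)(=O)Cc3ccc(Cl)cc3)CC1)COC2=O`) gives 4420 nM as the only number so far. Compound 2 (`N#Cc1cc2c(nc1N1CCC(C(=O)NS(=O)(=O)C(F)(F)c3ccccc3)CC1)COC2=O`) stands at "not determined" (no result reported) and so offers no starting value. Compound 3 (`N#Cc1cc2c(nc1N1CCC(C(=O)NS(=O)(=O)Cc3ccc(F)cc3)CC1)COC2=O`) is still to be measured. The change is 4-fluorobenzyl in place of difluoro(phenyl)methyl on a sulfonyl sulfur and puts 4-fluorobenzyl in place of difluoro(phenyl)methyl on a sulfonyl sulfur. No measured step sizes this change. Compound 1 at 4420 nM is the only anchor, and no step beyond the scatter from that value is expected in this assay for the new compound. In this assay the estimate for compound 3 is 5000 nM with an expected range from 2000 nM to 12000 nM for a single measurement.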

Compound 3, half-maximal inhibitory concentration: 3500 nM
Estimate against measurement, compound 3: 1.4-fold (0.15 log units) above; measured number inside the range.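

In this assay, fluoro in place of chloro on an aromatic carbon gives a 1.3-fold lower number from compound 1 to compound 3 (0.10 log units; within the scatter) and so leaves the read-out unmoved for this one halogen swap. The step from compound 2 to compound 3 cannot be read, since compound 2 has no number, and the difluoro(phenyl)methyl group therefore remains unsized. No supporting data bear on this result. Open, on these data alone, is whether a longer chain, or a group carrying an amine or a carboxylic acid, on the sulfonyl sulfur would shift the read-out beyond the scatter.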